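Replacing Methoxy with Cyano on the Benzimidazole-Bearing Acid

A few compounds are considered here, and "the series" means these few. Any claim that something is new, unique, unknown or untested is made for them only; others in the source may bear on it.

Measured so far in an assay on isolated protein for inhibition of protein kinase C zeta type (Homo sapiens), read by 33P incorporation, tested at 200 uM; a lower number here means a weaker effect, a higher number a stronger effect of the compound at the concentration tested:
compound 1, `O=C(O)CC(Cc1nc2cc(Cl)ccc2[nH]1)c1ccc(Cl)cc1`, gives 70%;
compound 2, `O=C(O)CC(Cc1nc2cc(F)ccc2[nH]1)c1ccc(Cl)cc1`, gives 30%;
compound 3, `COc1ccc2[nH]c(CC(CC(=O)O)c3ccc(Cl)cc3)nc2c1`, gives 0%.

Compound 3 stands lowest of the three numbers: a number 70 percentage points lower from compound 1 to compound 3 (beyond the scatter) and a number 30 percentage points lower from compound 2 to compound 3 (beyond the scatter) both lie beyond the scatter, so it is the weakest of the measured compounds in this assay. Compound 4, `N#Cc1ccc2[nH]c(CC(CC(=O)O)c3ccc(Cl)cc3)nc2c1`, differs from compound 3 by cyano in place of methoxy on an aromatic carbon. Going by the values given here, no measured step involves a cyano group, so the two steps onto compound 3 tell only that methoxy sits at the bottom; they do not say whether cyano behaves like a halogen or like methoxy. The step is therefore expected to be small to modest and upward, a number 20 percentage points higher from compound 3 to compound 4 (beyond the scatter), with wide uncertainty. Compound 4 is estimated at 20%, between 0% and 50%.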

Compound 4, a percentage reported as inhibition, at one concentration (the size of the read-out at that concentration, not a potency): 0%
Compound 4: middle estimate off by 20 percentage points, on the high side; measured number inside the range.
By their numbers in this assay, from the lowest: compounds 3 and 4 (each within the scatter of the next); then compound 2; then compound 1.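

In this assay, swapping methoxy for cyano at this position leaves the reading where it was, with no change at the digits printed from compound 3 to compound 4 (within the scatter) and no sign of recovery. Cyano also falls short of both halogens, with a number 30 percentage points lower from compound 2 to compound 4 (beyond the scatter) and with a number 70 percentage points lower from compound 1 to compound 4 (beyond the scatter) on the same scale, so among these four compounds only the fluoro and chloro ones show inhibition at the concentration tested. Nothing available here explains why this result arises. Still open, from the compounds shown here alone, is how bromo, methyl or an amine would read at this position, and whether any group could surpass chloro.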